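This account rests on a few compounds, and the source may have more. Where it says the series, first, only, none or still open, it means among the compounds named here.

Compound 2 `Cc1ccc(OCC(=O)NNC(=O)c2cc3ccccc3oc2=O)c(C(=O)c2cccc(Br)c2)c1` gives 71900 nM in a functional assay on DLA cells (Mus musculus) for cytotoxicity, read by trypan blue exclusion, with a stated time of 48 h; a higher number here means a weaker inhibitor, a lower number a stronger inhibitor. Compound 1 `Cc1ccc(OCC(=O)NNC(=O)c2cc3ccccc3oc2=O)c(C(=O)c2ccccc2)c1` gives 89100 nM in this assay, and the two numbers lie within the scatter of each other, the step being a 1.2-fold lower number from compound 1 to compound 2 (0.09 log units; within the scatter). Compound 3 `Cc1ccc(OCC(=O)NNC(=O)c2cc3ccccc3oc2=O)c(C(=O)c2ccc(F)cc2)c1` differs from compound 2 by 4-fluorophenyl in place of 3-bromophenyl on a carbonyl carbon. Going by the values given here, the only measured step that bears on this change is the one from compound 1 to compound 2, which also concerned a halogen on that phenyl and stayed within the scatter, so no step beyond the scatter is expected here. Compound 3 is therefore expected to give 80000 nM (range 35000 nM to 180000 nM), an estimated step of a 1.1-fold higher number from compound 2 to compound 3 (0.05 log units; within the scatter).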

Compound 3, half-maximal inhibitory concentration: 46100 nM
Compound 3: the middle estimate sits 1.7-fold (0.24 log units) above what was measured; the range from low to high includes it.
By their numbers in this assay, from the lowest: compounds 3, 2 and 1 (each within the scatter of the next).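

In this assay, swapping 3-bromophenyl for 4-fluorophenyl on this carbonyl carbon changes both the halogen and its ring position, yet the result stays within the scatter (a 1.6-fold lower number from compound 2 to compound 3 (0.19 log units; within the scatter)). Fluoro in place of hydrogen on the aromatic carbon of the plain phenyl also stays within it (a 1.9-fold lower number from compound 1 to compound 3 (0.29 log units; within the scatter)), so all three phenyl variants remain indistinguishable here. No evidence is available that bears on these small differences.

Going by these compounds, whether an amine or a carboxylic acid on this phenyl would move the number beyond the scatter stays open. So does the effect of a longer chain in place of the phenyl.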